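Methyl for chloro on the dimethoxyphenoxy ether ring

The source may hold more compounds than are shown below. What is called first, only, known or untested is meant among the compounds shown, and "the series" means these compounds.

Among the compounds with values here, in a functional assay (strain Wistar) for antagonist activity at Alpha-1A adrenergic receptor (Rattus norvegicus) (a higher number here means a more potent compound, by a factor of ten per unit of this negative logarithm, a lower number a less potent compound), compound 2 `COc1cccc(Cl)c1OCCNCCOc1ccccc1OCc1ccccc1` gives 8.16, the low end of the two numbers so far, within the scatter of compound 1 `COc1cccc(OC)c1OCCNCCOc1ccccc1OCc1ccccc1`, which gives 8.39; the step of a number 0.23 log units lower from compound 1 to compound 2 (within the scatter) does not leave the scatter. Compound 3 `COc1cccc(C)c1OCCNCCOc1ccccc1OCc1ccccc1` carries the change (methyl in place of chloro on an aromatic carbon). Within the data shown here, the only measured step at this position, chloro in place of methoxy, moved the number by less than the scatter, and no measured pair sets methyl against chloro. A step of comparable size, in no settled direction, is therefore expected, a number 0.04 log units higher from compound 2 to compound 3 (within the scatter). Compound 3 is estimated at 8.2, between 7.7 and 8.7.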

Compound 3, negative logarithm of the antagonist equilibrium constant: 8.35
The estimate for compound 3 lay 0.15 log units below the measured number, within the range that was stated.
By their numbers in this assay, from the lowest: compounds 2, 3 and 1 (each within the scatter of the next).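

In this assay, two further steps at this position, a number 0.19 log units higher from compound 2 to compound 3 (within the scatter) and a number 0.04 log units lower from compound 1 to compound 3 (within the scatter), both stay within the scatter. Methyl, chloro and methoxy therefore cannot be told apart here, and no order among the three can be read from these numbers. Nothing available bears on why these groups give such close numbers. The compounds shown leave open whether an amine, a carboxylic acid or a longer chain such as butyl at this position would give a number outside the scatter of these three.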